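A few compounds are considered here, and "the series" means these few. Any claim that something is new, unique, unknown or untested is made for them only; others in the source may bear on it.

Measured compounds:
compound 1 `COc1ccc(N)c(C2=NN(C(=O)C3CC3)C(C)(C)S2)c1`: 90.1%
compound 2 `COc1ccc(N)c(C2=NN(C(=O)C3CCC3)C(C)(C)S2)c1`: 57.8%

Both numbers come from an assay on isolated protein for inhibition of Nitric oxide synthase, inducible (Homo sapiens), read by scintillation counting, with a stated time of 30 min, tested at 50 uM; on this read-out lower numbers stand for less inhibition and higher numbers for more inhibition at the one concentration tested (going by the name of the read-out). Going by the values given here, compound 2 stands lowest of the two; its only neighbour, compound 1, lies higher by the step of a number 32.3 percentage points lower from compound 1 to compound 2 (beyond the scatter). Compound 3 `COc1ccc(N)c(C2=NN(C(=O)c3ccccc3)C(C)(C)S2)c1` is not yet measured. It differs from compound 2 by phenyl in place of cyclobutyl on a carbonyl carbon, on a carbonyl carbon whose other neighbour is an amide-type nitrogen in a ring. Among the compounds with values here, only the step of a number 32.3 percentage points lower from compound 1 to compound 2 (beyond the scatter) bears on this, and loosely: it also replaced the ring on this carbonyl carbon by a larger one and lowered inhibition beyond the scatter. A further, uncertain drop is expected, as the step of a number 15.8 percentage points lower from compound 2 to compound 3 (beyond the scatter). For compound 3 the estimate is 42%, within 15% to 72%.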

Compound 3, a percentage reported as inhibition, at one concentration (the size of the read-out at that concentration, not a potency): 0%
For compound 3 the middle estimate is 42 percentage points above the measured one; the whole stated range lies above it.
By their numbers in this assay, from the lowest: compound 3; then compound 2; then compound 1.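

Phenyl on this carbonyl carbon costs far more than the enlargement from cyclopropyl to cyclobutyl did (a number 57.8 percentage points lower from compound 2 to compound 3 (beyond the scatter)), and compared with cyclopropyl the loss is larger still (a number 90.1 percentage points lower from compound 1 to compound 3 (beyond the scatter)). With compound 3 at (0%), no inhibition is left at the one concentration tested, so this position accepts some rings but not phenyl. No measurement here explains why phenyl behaves so differently. Going by these compounds, whether a ring is needed at all remains open, and so does how an open butyl chain or an amine on this carbonyl carbon would fare.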